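Amine isomers on the shared core: outlook for compound 3

This account rests on a few compounds, and the source may have more. Where it says the series, first, only, none or still open, it means among the compounds named here.

Within the data shown here, compound 2 `CCC(CC)Nc1nc(C)nc2c(-c3c(C)cc(OC)cc3OC)c(C)nn12` carries a (pentan-3-yl)amino group on the shared core and in an assay on cell membranes for displacement of a labelled ligand from corticotropin-releasing factor receptor 1 (Rattus norvegicus) (a lower number here means a stronger inhibitor, a higher number a weaker inhibitor), gives 5 nM, the higher of the two numbers known. Among the measured compounds shown here, compound 1 `CCCCN(CC)c1nc(C)nc2c(-c3c(C)cc(OC)cc3OC)c(C)nn12` gives 1.72 nM in this assay, and the single step between the two is a 2.9-fold higher number from compound 1 to compound 2 (0.46 log units; beyond the scatter), which places compound 2 at the top of the set by a margin beyond the scatter.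

Compound 3 `CCCC(C)Nc1nc(C)nc2c(-c3c(C)cc(OC)cc3OC)c(C)nn12` is the next member. Its change from compound 2 is 1-methylbutyl in place of pentan-3-yl on a nitrogen on an aromatic ring. For the measured compounds named here, no measured step bears on this change directly. Going by the values given here, the only step available, a 2.9-fold higher number from compound 1 to compound 2 (0.46 log units; beyond the scatter), exchanges butyl(ethyl)amino for (pentan-3-yl)amino and is modest in size; the change to compound 3 rearranges the same atoms of the same amino group without altering what is counted, and is expected to matter less. The step to compound 3 is therefore expected to be no change at the digits printed from compound 2 to compound 3 (within the scatter), within the scatter in either direction. Compound 3 is expected to give 5 nM in this assay, with a range from 2 nM to 12 nM.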

Compound 3, half-maximal inhibitory concentration: 2.14 nM
Compound 3: middle estimate off by 2.3-fold (0.37 log units), on the high side; low and high end bracket the measured number.
By their numbers in this assay, from the lowest: compounds 1 and 3 (each within the scatter of the next); then compound 2.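

In this assay, the exchange of pentan-3-yl for 1-methylbutyl on a nitrogen on an aromatic ring gives a 2.3-fold lower number from compound 2 to compound 3 (0.37 log units; beyond the scatter) even though the two groups hold the same atoms, joined differently, so at this position the arrangement of the chain alone can move the number beyond the scatter. The (1-methylbutyl)amino group also shows a 1.2-fold higher number from compound 1 to compound 3 (0.09 log units; within the scatter) against butyl(ethyl)amino, so the gap between compound 1 and compound 2 does not come with every (pentan-3-yl)amino-type isomer and, among these three compounds, only compound 2 stands apart from the others. No measured information is at hand to explain either step, and the numbers record only that the two arrangements differ.

Going by these compounds, it remains open whether other arrangements of the chain on this nitrogen, such as a straight pentyl chain or a cyclopentyl ring, would sit with compound 2 or with compound 1 and compound 3. Also open, on these data alone, is how a longer chain such as hexan-3-yl, or a chain carrying an ether oxygen, would behave at the same place on the shared core.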